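The source may hold more compounds than are shown below. What is called first, only, known or untested is meant among the compounds shown, and "the series" means these compounds.

Of the compounds shown here, three sharing one core have been tested in an in vitro ADME assay on microsomes from liver (Mus musculus) for pharmacokinetics, read by LC-MS, with a stated time of 10 min, tested at 1 uM (a higher number here means faster removal of the compound, a lower number slower removal), and they differ in the group on an amine nitrogen in a ring. Compound 1 `CC(C)N1C[C@H](C(=O)Nc2ccc(Cl)cc2)[C@@H](c2ccc(/C=C/C(=O)Nc3ccccc3N)cc2)C1`, with isopropyl, gives 38 mL/min/kg. Compound 2 `Nc1ccccc1NC(=O)/C=C/c1ccc([C@H]2CN(C3COC3)C[C@@H]2C(=O)Nc2ccc(Cl)cc2)cc1`, with oxetan-3-yl, gives 42 mL/min/kg. Compound 3 `CC(C)(C)N1C[C@H](C(=O)Nc2ccc(Cl)cc2)[C@@H](c2ccc(/C=C/C(=O)Nc3ccccc3N)cc2)C1`, with tert-butyl, gives 20 mL/min/kg, the lowest of the three numbers, though it is clearly separated only from compound 2.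

Compound 4 `CC(C)(CO)N1C[C@H](C(=O)Nc2ccc(Cl)cc2)[C@@H](c2ccc(/C=C/C(=O)Nc3ccccc3N)cc2)C1` changes compound 3 at one place: hydroxy in place of hydrogen on a saturated chain carbon, two bonds along the chain from an amine nitrogen in a ring. This puts hydroxy in place of hydrogen on a saturated chain carbon, two bonds along the chain from an amine nitrogen in a ring, turning tert-butyl into 1-(hydroxymethyl)-1-methylethyl.

Going by the values given here, no measured step adds a hydroxy, so the evidence is indirect. Swaps at that nitrogen gave a 1.1-fold higher number from compound 1 to compound 2 (0.04 log units; within the scatter), a 1.9-fold lower number from compound 1 to compound 3 (0.28 log units; within the scatter) and, as the only modest step beyond the scatter, a 2.1-fold lower number from compound 2 to compound 3 (0.32 log units; beyond the scatter). From these small steps, the expected result is a 1.1-fold higher number from compound 3 to compound 4 (0.04 log units; within the scatter), with no step beyond the scatter expected in either direction. Compound 4 is estimated at 22 mL/min/kg, with an expected range from 11 mL/min/kg to 42 mL/min/kg.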

Compound 4, clearance: 40 mL/min/kg
Compound 4: the middle estimate sits 1.8-fold (0.26 log units) below what was measured; the range from low to high includes it.
By their numbers in this assay, from the lowest: compounds 3, 1, 4 and 2 (each within the scatter of the next, the first and the last beyond it).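

Hydroxy in place of hydrogen on a saturated chain carbon, two bonds along the chain from an amine nitrogen in a ring, is a new kind of change at this nitrogen substituent, and in this assay it gives (a 2.0-fold higher number from compound 3 to compound 4 (0.30 log units; within the scatter)). Going by these compounds alone, the 1-(hydroxymethyl)-1-methylethyl group also stays within the scatter of oxetan-3-yl (a 1.1-fold lower number from compound 2 to compound 4 (0.02 log units; within the scatter)) and of isopropyl (a 1.1-fold higher number from compound 1 to compound 4 (0.02 log units; within the scatter)), so tert-butyl remains the only group here with a step beyond the scatter, and only against oxetan-3-yl. Nothing measured here gives a reason for this result.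

Still open, going by these compounds, is how a methoxymethyl group, which caps that oxygen, would compare with hydroxymethyl in the same place. So is the reading for a carboxylic acid, an aminomethyl group or a longer hydroxyalkyl chain there.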